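From nitro to methoxy on the shared core

The source may report more compounds than this note shows. Statements on the series, on what has been measured and on what is new or still open speak of the compounds shown alone.

Two values frame the series: in a functional assay on SJ-G2 cells (Homo sapiens) for cytotoxicity, read by MTT assay, with a stated time of 72 h (a lower number here means a stronger inhibitor of growth, a higher number a weaker inhibitor of growth), compound 1 (`Cc1ccc(/C=C(/C#N)C(=O)c2ccc[nH]2)cc1`) gives 20000 nM while compound 3 (`N#C/C(=C/c1ccc(Cl)c(Cl)c1)C(=O)c1ccc[nH]1`) gives 10000 nM in the same test, and these two lie within the scatter of each other. Compound 2 (`N#C/C(=C/c1ccc([N+](=O)[O-])cc1)C(=O)c1ccc[nH]1`) reads < 10000 nM there, which is a limit of the assay and not a number.

Compound 4 (`COc1ccc(/C=C(/C#N)C(=O)c2ccc[nH]2)cc1`) carries methoxy in place of nitro on an aromatic carbon, para to a large group. Among the compounds with values here, one measured step bears on this, namely an at least 2.0-fold lower number from compound 1 to compound 2 (0.30 log units; that floor lies within the scatter) with nitro in place of methyl, and its floor lies within the scatter. Methoxy is not the methyl of compound 1 at 20000 nM and the guide is loose, yet a return toward that value is expected. The expected change is an at least 1.5-fold higher number from compound 2 to compound 4 (0.17 log units; that floor lies within the scatter) in this assay and would be a small move to a higher number that may stay within the scatter. In this assay compound 4 is estimated at 15000 nM with 6000 nM to 40000 nM as the expected range.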

Compound 4, concentration for 50% growth inhibition: < 10000 nM
Compound 4: a limit, no number; the forecaster's own chance of this, stated with the estimate: 20%; middle value at least 1.5-fold (0.17 log units) away from the limit.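

In this assay compound 4 reads < 10000 nM, which is a limit of the assay and not a number. Methoxy at this place, para to a large group, therefore gives a reading of the same kind as nitro, and the change from methyl to methoxy is an at least 2.0-fold lower number from compound 1 to compound 4 (0.30 log units; that floor lies within the scatter), a step whose floor does not clear the scatter. The step between compound 2 and compound 4 cannot be read, so the result does not rank methoxy against nitro, and both compounds now rest on the same limit: the limit of < 10000 nM in this assay, at which 2 of the 4 values shown sit.

On these data alone, how far the true values of compound 2 and compound 4 lie from that limit remains open. Also open, as far as these compounds go, is whether an amine, a carboxylic acid or a longer chain such as ethoxy at this place would give a number rather than a limit.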